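This account rests on a few compounds, and the source may have more. Where it says the series, first, only, none or still open, it means among the compounds named here.

Measured so far in an ADME assay on GES1 cells (Homo sapiens) for cytotoxicity, read by MTT assay, with a stated time of 24 h; on this read-out lower numbers stand for higher toxicity in this test and higher numbers for lower toxicity in this test:
compound 1 `Cc1ccccc1-n1cc(-c2ccccc2NS(=O)(=O)c2c[nH]c(=O)[nH]c2=O)nn1` gives 19900 nM;
compound 2 `O=c1[nH]cc(S(=O)(=O)Nc2ccccc2-c2cn(-c3ccc(Cl)cc3)nn2)c(=O)[nH]1` gives 26700 nM;
compound 3 `Cc1ccc(-n2cc(-c3cccc(NS(=O)(=O)c4c[nH]c(=O)[nH]c4=O)c3)nn2)cc1` gives 15800 nM.

Compound 3 carries the lowest of the three numbers, but its gaps to compound 1 and to compound 2 both lie within the scatter, so the three compounds stand level in this assay and no order among them can be read. For the measured compounds named here, the only step between measured compounds that differ in one place, a 1.3-fold higher number from compound 1 to compound 2 (0.13 log units; within the scatter), is itself within the scatter: exchanging one substituted phenyl for another on the aromatic nitrogen left the number where it was.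

Compound 4 `O=c1[nH]cc(S(=O)(=O)Nc2cccc(-c3cn(-c4ccc(F)cc4)nn3)c2)c(=O)[nH]1` differs from compound 3 by fluoro in place of methyl on an aromatic carbon. Going by the values given here, no measured step covers this exact exchange; the one step that bears on it, the phenyl-for-phenyl swap from compound 1 to compound 2, produced nothing beyond the scatter. Compound 4 is therefore expected to stay close to compound 3, with an expected step of a 1.1-fold higher number from compound 3 to compound 4 (0.03 log units; within the scatter) and no direction beyond the scatter. The estimate for compound 4 in this assay is 17000 nM, expected to fall between 8000 nM and 40000 nM.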

Compound 4, half-maximal cytotoxic concentration: "not toxic" (no number reported)
The entry for compound 4 holds no number; there is nothing to compare the estimate with.
By their numbers in this assay, from the lowest: compounds 3, 1 and 2 (each within the scatter of the next).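

For the compounds shown here, compound 4 is entered in this assay as "not toxic" without a number, so no step from compound 3 to compound 4 can be read. No measured evidence bears on this result. From the compounds shown here alone, whether 4-fluorophenyl in place of 4-methylphenyl shifts the number remains open.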